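This account rests on a few compounds, and the source may have more. Where it says the series, first, only, none or still open, it means among the compounds named here.

Measured so far:
compound 1 `c1ccc(CSc2nnc(-c3ccc4c(c3)OCCO4)n2-c2ccccc2)cc1` gives 32800 nM in a functional assay on HeLa cells (Homo sapiens) for antiproliferative activity, read by MTT assay, with a stated time of 24 h; on this read-out lower numbers stand for stronger inhibition and higher numbers for weaker inhibition.
compound 2 `O=[N+]([O-])c1ccccc1CSc1nnc(-c2ccc3c(c2)OCCO3)n1-c1ccccc1` gives 69800 nM in this assay.

Compound 2 stands at the highest of the two numbers measured: compound 1 sits a 2.1-fold higher number from compound 1 to compound 2 (0.33 log units; beyond the scatter) below it. That single step is the only one recorded, and it shows that adding the nitro group raised the number modestly.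

Compound 3 `Fc1ccc(CSc2nnc(-c3ccc4c(c3)OCCO4)n2-c2ccccc2)c(F)c1` has not yet been measured. It differs from compound 2 in one place: 2,4-difluorophenyl in place of 2-nitrophenyl on a saturated chain carbon bound to a sulfur. The nitro group that marked the step from compound 1 to compound 2 is gone here. As far as these compounds go, nothing in the measured pair speaks to the two fluorines, so their contribution is unknown. The expectation for compound 3 is therefore a return toward the number of compound 1, roughly a 1.9-fold lower number from compound 2 to compound 3 (0.29 log units; within the scatter) in this assay, with wide uncertainty. Compound 3 is estimated at 36000 nM, ranging from 14000 nM to 90000 nM.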

Compound 3, half-maximal inhibitory concentration: 18600 nM
Estimate against measurement, compound 3: 1.9-fold (0.29 log units) above; the range from low to high includes it.
By their numbers in this assay, from the lowest: compounds 3 and 1 (each within the scatter of the next); then compound 2.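

In this assay, 2,4-difluorophenyl in place of 2-nitrophenyl on a saturated chain carbon bound to a sulfur gives a 3.8-fold lower number from compound 2 to compound 3 (0.57 log units; beyond the scatter) and so shows that the number at this position depends on what the ring carries. Against plain phenyl, the same group gives a 1.8-fold lower number from compound 1 to compound 3 (0.25 log units; within the scatter) and thus leaves compound 1 and compound 3 indistinguishable, so among these three compounds only the 2-nitrophenyl of compound 2 stands apart. Nothing available here explains why these groups differ.

Open, as far as these compounds go, is whether any group on this ring can take the number beyond the scatter of compound 1 in the favourable direction. A methoxy group or an amine on the ring, or a longer chain between the sulfur and the ring, could help to answer this.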